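Methoxy to ethoxy on a dibenzylidene cyclohexanone scaffold

The compounds below may be only part of what the source reports. "The series", "measured", "known", "first", "only" and "open" are said of these compounds alone.

The study follows a small series of compounds sharing one core. Compound 1 `CCOc1c(Br)cc(/C=C2\CCC/C(=C\c3cccc([N+](=O)[O-])c3)C2=O)cc1OC`, compound 2 `COc1cc(/C=C2\CCC/C(=C\c3ccc([N+](=O)[O-])cc3)C2=O)cc(Br)c1O` and compound 3 `COc1cc(/C=C2\CCC/C(=C\c3ccc([N+](=O)[O-])cc3)C2=O)cc(Br)c1OC` have been tested, and compound 4 `CCOc1c(Br)cc(/C=C2\CCC/C(=C\c3ccc([N+](=O)[O-])cc3)C2=O)cc1OC` has not. In a functional assay on SK-N-MC cells (Homo sapiens) for cytotoxicity, read by MTT assay (on this read-out higher numbers stand for weaker inhibition and lower numbers for stronger inhibition), compound 3 gives 9.86 ug/mL, the lowest of the three numbers, although its distance to compound 1 and to compound 2 stays within the scatter. In this assay compound 1 gives 10.8 ug/mL and compound 2 gives 16.8 ug/mL.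

Compound 4 differs from compound 3 by methyl in place of hydrogen on a saturated chain carbon bound to an oxygen on an aromatic ring. For the measured compounds named here, no measured pair carries exactly this change. The nearest measured step, a 1.7-fold lower number from compound 2 to compound 3 (0.23 log units; within the scatter), adds a methyl on the ring oxygen and stays within the scatter. Compound 1 already bears the ethoxy group, and its number sits close to that of compound 3. On this basis no step beyond the scatter is expected in this assay, and the expected step is a 1.0-fold higher number from compound 3 to compound 4 (0.01 log units; within the scatter). Compound 4 is therefore estimated at 10 ug/mL, within a range from 5 ug/mL to 20 ug/mL.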

Compound 4, half-maximal inhibitory concentration: 3.91 ug/mL
Compound 4: the middle estimate sits 2.6-fold (0.41 log units) above what was measured; the whole stated range lies above it.
By their numbers in this assay, from the lowest: compound 4; then compounds 3, 1 and 2 (each within the scatter of the next).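

Extending methoxy to ethoxy gives a 2.5-fold lower number from compound 3 to compound 4 (0.40 log units; beyond the scatter) in this assay, so this oxygen substituent can shift the number beyond the scatter, which the earlier 1.7-fold lower number from compound 2 to compound 3 (0.23 log units; within the scatter) on adding methyl to the same oxygen did not show. Taken together, ethyl in place of the hydrogen on that oxygen gives a 4.3-fold lower number from compound 2 to compound 4 (0.63 log units; beyond the scatter) in this assay, the largest of the steps here. The ethoxy result also depends on the other end of the molecule, since 4-nitrophenyl in place of 3-nitrophenyl gives a 2.8-fold lower number from compound 1 to compound 4 (0.44 log units; beyond the scatter) with the ethoxy group kept.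

Nothing available explains these steps.

On these data alone, whether a propoxy group or a longer chain on this oxygen would extend the trend remains open, as does whether an amine on the chain end would keep it.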